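A few compounds are considered here, and "the series" means these few. Any claim that something is new, unique, unknown or untested is made for them only; others in the source may bear on it.

Of the compounds shown here, three built on one shared core have been tested in a functional assay on HepG2 cells (Homo sapiens) for antiproliferative activity, read by MTT assay, with a stated time of 48 h; on this read-out higher numbers stand for weaker inhibition and lower numbers for stronger inhibition. Compound 1 `Cc1cccc(-n2nncc2CN2C(=O)C3(C(C#N)=C(N)Oc4c(N)cc5nc6ccccc6nc5c43)c3ccccc32)c1` carries a 3-methylphenyl on an aromatic nitrogen of the five-membered aromatic ring with three nitrogens; in this assay compound 1 gives only a limit, > 50000 nM. Compound 2 `N#CC1=C(N)Oc2c(N)cc3nc4ccccc4nc3c2C12C(=O)N(Cc1cnnn1-c1cccc(Br)c1)c1ccccc12` carries a 3-bromophenyl on that nitrogen; in this assay compound 2 likewise gives only a limit, > 50000 nM. Going by the values given here, compound 3 `N#CC1=C(N)Oc2c(N)cc3nc4ccccc4nc3c2C12C(=O)N(Cc1cnnn1-c1ccccc1Br)c1ccccc12` carries a 2-bromophenyl there, and in this assay compound 3 gives 38000 nM, the only actual number among the three, the other two resting at the limit of > 50000 nM in this assay, at which 2 of the 3 values shown sit.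

Compound 4 `COc1ccc(-n2nncc2CN2C(=O)C3(C(C#N)=C(N)Oc4c(N)cc5nc6ccccc6nc5c43)c3ccccc32)cc1` differs from compound 3 in one place: 4-methoxyphenyl in place of 2-bromophenyl on an aromatic nitrogen. The measured steps that bear on such a swap of the aryl group are an at least 1.3-fold lower number from compound 1 to compound 3 (0.11 log units; that floor lies within the scatter) and an at least 1.3-fold lower number from compound 2 to compound 3 (0.11 log units; that floor lies within the scatter); both are floors lying inside the scatter, so neither earlier swap has moved the read-out by a readable amount. The step that the two limits leave unreadable from compound 1 to compound 2 cannot be read from two limits. Nothing therefore points to a step beyond the scatter in this assay in either direction, and a return to the limit is as plausible as a small gain. Compound 4 is expected to give about 45000 nM, between 20000 nM and 150000 nM, which means an expected step of a 1.2-fold higher number from compound 3 to compound 4 (0.07 log units; within the scatter).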

Compound 4, half-maximal inhibitory concentration: > 50000 nM
Compound 4: a limit, no number; the forecaster's own chance of this, stated with the estimate: 55%; at least 1.1-fold (0.04 log units) between middle value and limit.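

Putting 4-methoxyphenyl in place of 2-bromophenyl on the aromatic nitrogen brings in an oxygen and a hydrogen-bond acceptor that the 2-bromophenyl does not have, yet in this assay this change gives only an at least 1.3-fold higher number from compound 3 to compound 4 (0.11 log units; that floor lies within the scatter). The result for compound 4 is a limit and not a number, so its steps from compound 1 and compound 2, which join one limit to another, cannot be read. With a methoxy group now added to the methyl and bromo groups already tried on this phenyl ring, no swap at this position has produced a step readable beyond the scatter, and most of the results gather at one value that is not a true number: the limit of > 50000 nM in this assay, at which 3 of the 4 values shown sit.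

On these data alone, it remains open whether an amine or a carboxylic acid on this phenyl ring, or a longer chain in place of the ring, would bring the read-out to a clearly measurable value. Also open, as far as these compounds go, is whether a change elsewhere would do more, since all four compounds keep the shared core unchanged, including its nitrile and its amines.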